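A Fluorine Swap at the Far End of the Core

This account rests on a few compounds, and the source may have more. Where it says the series, first, only, none or still open, it means among the compounds named here.

Three compounds share one core and differ only in the group hanging from one end of it. Compound 1 `CC(C)(C)c1ccc(-c2ccc(-c3ccc(C(=N)N)cc3)o2)cc1` carries a tert-butyl group, compound 2 `Cc1ccc(-c2ccc(-c3ccc(C(=N)N)cc3)o2)cc1` a methyl group, and compound 3 `N=C(N)c1ccc(-c2ccc(-c3ccc([N+](=O)[O-])cc3)o2)cc1` a nitro group. In a functional assay on MDA-MB-231 cells (Homo sapiens) for cytotoxicity, read by MTT assay, with a stated time of 96 h (a lower number here means a stronger inhibitor, a higher number a weaker inhibitor), compound 1 gives 3200 nM, compound 2 gives 3400 nM and compound 3 gives 3100 nM. Compound 2 sits among these three with every gap inside the scatter: the step of a 1.1-fold higher number from compound 1 to compound 2 (0.03 log units; within the scatter), the step of a 1.1-fold lower number from compound 2 to compound 3 (0.04 log units; within the scatter), and the step of a 1.0-fold lower number from compound 1 to compound 3 (0.01 log units; within the scatter) all show that changing this group left the read-out essentially unmoved.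

Compound 4 `N=C(N)c1ccc(-c2ccc(-c3cccc(F)c3)o2)cc1` takes this further. Compared with compound 2 the change is 3-fluorophenyl in place of 4-methylphenyl on an aromatic carbon. Among the compounds with values here, no measured step involves a fluorine or a 3-substituted ring, so the guide is indirect: the three steps above suggest the group at this position has little effect. The step from compound 2 to compound 4 is therefore expected to be no change at the digits printed from compound 2 to compound 4 (within the scatter), with no shift beyond the scatter. Compound 4 is estimated at 3400 nM, within a range from 1500 nM to 7500 nM.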

Compound 4, half-maximal inhibitory concentration: 2000 nM
Beside the measured number, compound 4's estimate is 1.7-fold (0.23 log units) above it, within the range that was stated.
By their numbers in this assay, from the lowest: compounds 4, 3, 1 and 2 (each within the scatter of the next).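

The earlier compounds shown here varied only a small group at one fixed spot on the end ring, whereas this change replaces 4-methylphenyl with 3-fluorophenyl, bringing in fluorine and moving the substituent to another ring position. Even so, the step is a 1.7-fold lower number from compound 2 to compound 4 (0.23 log units; within the scatter), so in this assay this position accepts a different substituent at a different ring position without a shift beyond the scatter. Nothing measured here offers an explanation for this result.

Fluorine and the new ring position arrive together in this one step, so their separate contributions cannot be told apart. As far as these compounds go, it also remains open whether a charged group at this end, such as an amine or a carboxylic acid, would leave the read-out just as unmoved.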